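The source may report more compounds than this note shows. Statements on the series, on what has been measured and on what is new or still open speak of the compounds shown alone.

In a functional assay on U2OS cells (Homo sapiens) for cytotoxicity, read by MTT assay, with a stated time of 48 h (on this read-out lower numbers stand for stronger inhibition and higher numbers for weaker inhibition), compound 1 `COc1ccc(Nc2nc(-c3cccc(F)c3)nc3ccc(F)cc23)cc1` gives 32300 nM. Compound 2 `Fc1cccc(-c2nc(Nc3ccccc3F)c3cc(F)ccc3n2)c1` reads > 50000 nM, which is a limit, not a number. Compound 3 `Fc1cccc(-c2nc(Nc3ccc(Br)cc3)c3cc(F)ccc3n2)c1` reads > 50000 nM, also a limit, so it stands at the limit of > 50000 nM in this assay, at which 2 of the 3 values shown sit. Compound 4 `Nc1ccc(Nc2nc(-c3cccc(F)c3)nc3ccc(F)cc23)cc1` has amino in place of bromo on an aromatic carbon, para to a large group: amino in place of bromo on an aromatic carbon. The closest measured change is an at least 1.5-fold higher number from compound 1 to compound 3 (0.18 log units; that floor lies within the scatter), with bromo in place of methoxy on an aromatic carbon. The step that the two limits leave unreadable from compound 2 to compound 3 adds nothing on size. A modest move toward lower numbers, and so stronger inhibition, is therefore expected, though another limit remains possible. The expected change is an at least 1.7-fold lower number from compound 3 to compound 4 (0.25 log units; that floor lies within the scatter). For compound 4 the estimate is 28000 nM, with an expected range of 10000 nM to 50000 nM.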

Compound 4, half-maximal inhibitory concentration: 44200 nM
The estimate for compound 4 lay 1.6-fold (0.20 log units) below the measured number; measured number inside the range.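

Amino on this aromatic carbon gives a readable number where bromo gave only a limit, but the floor of that step lies within the scatter (an at least 1.1-fold lower number from compound 3 to compound 4 (0.05 log units; that floor lies within the scatter)), as does the floor of the step that replaces the whole 2-fluorophenyl group (an at least 1.1-fold lower number from compound 2 to compound 4 (0.05 log units; that floor lies within the scatter)). Against methoxy on the same carbon, amino makes no readable difference in this assay (a 1.4-fold higher number from compound 1 to compound 4 (0.14 log units; within the scatter)). The other two steps among these compounds cannot be read, and compound 2 and compound 3 each remain at a limit: the limit of > 50000 nM in this assay, at which 2 of the 4 values shown sit.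

Going by these compounds, how far compound 3 actually lies from compound 4 stays open. On these data alone, whether a dimethylamino group or a carboxylic acid on this carbon would move the number beyond the scatter also stays open.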